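A few compounds are considered here, and "the series" means these few. Any claim that something is new, unique, unknown or untested is made for them only; others in the source may bear on it.

Three compounds share one core and differ only in the group attached to the amine nitrogen of the five-membered ring. In a functional assay on U2OS cells for antagonist activity at proto-oncogene Wnt-3 (Homo sapiens), read by a luciferase reporter, with a stated time of 18 h (a lower number here means that less compound is needed, a higher number that more compound is needed for the effect), compound 1 `CC(=O)N1CCC[C@H]1C(=O)N1CCC(NS(=O)(=O)c2cc(S(=O)(=O)c3ccccc3)ccc2C(F)(F)F)CC1` gives 250 nM, compound 2 `O=C([C@@H]1CCCN1C(=O)c1ccncc1)N1CCC(NS(=O)(=O)c2cc(S(=O)(=O)c3ccccc3)ccc2C(F)(F)F)CC1` gives 350 nM, and compound 3 `CC(C)(C)NC(=O)N1CCC[C@H]1C(=O)N1CCC(NS(=O)(=O)c2cc(S(=O)(=O)c3ccccc3)ccc2C(F)(F)F)CC1` gives 30 nM, the lowest of the three numbers. The steps of an 8.3-fold lower number from compound 1 to compound 3 (0.92 log units; beyond the scatter) and a 12-fold lower number from compound 2 to compound 3 (1.07 log units; beyond the scatter) show that the group on this nitrogen moves the number well beyond the scatter, while a 1.4-fold higher number from compound 1 to compound 2 (0.15 log units; within the scatter) stays within it. Compound 4 `CC(C)(C)CCN1CCC[C@H]1C(=O)N1CCC(NS(=O)(=O)c2cc(S(=O)(=O)c3ccccc3)ccc2C(F)(F)F)CC1` carries the change (3,3-dimethylbutyl in place of (tert-butyl)carbamoyl on an amine nitrogen in a ring). Within the data shown here, no measured step removes the carbonyl and the amide hydrogen from this position in the same way, so the closest guidance is that the two other groups tried there gave higher numbers than compound 3. On that basis compound 4 is expected to give a higher number than compound 3 in this assay, with the step of a 6.7-fold higher number from compound 3 to compound 4 (0.82 log units; beyond the scatter), and its estimate is 200 nM, in a range from 40 nM to 1000 nM.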

Compound 4, half-maximal effective concentration: 450 nM
Compound 4: middle estimate off by 2.3-fold (0.35 log units), on the low side, and the stated range covers the measured number.
By their numbers in this assay, from the lowest: compound 3; then compounds 1, 2 and 4 (each within the scatter of the next).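

In this assay, the step of a 15-fold higher number from compound 3 to compound 4 (1.18 log units; beyond the scatter) shows that keeping the tert-butyl end while replacing (tert-butyl)carbamoyl with the all-carbon 3,3-dimethylbutyl chain does not preserve the low number of compound 3. The steps of a 1.3-fold higher number from compound 2 to compound 4 (0.11 log units; within the scatter) and a 1.8-fold higher number from compound 1 to compound 4 (0.26 log units; within the scatter) place this chain level with the acetyl and (pyridin-4-yl)carbonyl groups, so among these four compounds only the (tert-butyl)carbamoyl group stands apart. No supporting evidence is available to explain this difference.

The compounds shown leave open whether the carbonyl, the amide hydrogen or both matter in the (tert-butyl)carbamoyl group. A 2,2-dimethylpropanoyl group, with a carbonyl but no amide hydrogen, would help separate these parts when compared directly with compound 3.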